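The source may hold more compounds than are shown below. What is called first, only, known or untested is meant among the compounds shown, and "the series" means these compounds.

In an ADME assay on the whole organism for inhibition, with Echinochloa crus-galli var. formosensis as the target, with a stated time of 4 days (on this read-out lower numbers stand for stronger inhibition and higher numbers for weaker inhibition), compound 3 (`CCCN(C)c1nc(Cl)nc(N[C@H](C)c2ccccc2)n1`) gives 9770 nM, the middle of three numbers, with compound 2 (`CNc1nc(Cl)nc(N[C@H](C)c2ccccc2)n1`) lower at 562 nM and compound 1 (`CCCCNc1nc(Cl)nc(N[C@H](C)c2ccccc2)n1`) higher at 38900 nM. Compound 4 (`CC(C)Nc1nc(Cl)nc(N[C@H](C)c2ccccc2)n1`) has isopropylamino in place of methyl(propyl)amino on an aromatic carbon. Shortening the chain gave a large step, a 69-fold lower number from compound 1 to compound 2 (1.84 log units; beyond the scatter), and the change of amino group gave a modest one, a 4.0-fold lower number from compound 1 to compound 3 (0.60 log units; beyond the scatter). Adding propyl to the nitrogen gave another large step, a 17-fold higher number from compound 2 to compound 3 (1.24 log units; beyond the scatter). No branched chain has been measured, so the forecast is loose. A modest drop is expected, with the estimated step of a 3.3-fold lower number from compound 3 to compound 4 (0.51 log units; beyond the scatter). The expected value for compound 4 is 3000 nM, within an estimated range of 600 nM to 15000 nM.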

Compound 4, half-maximal inhibitory concentration: 2000 nM
Compound 4: middle estimate off by 1.5-fold (0.18 log units), on the high side; low and high end bracket the measured number.
By their numbers in this assay, from the lowest: compound 2; then compound 4; then compound 3; then compound 1.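

Isopropylamino, the first branched chain at this position, falls in the middle of the series: a 19-fold lower number from compound 1 to compound 4 (1.29 log units; beyond the scatter) marks a large gain over butylamino, while a 3.6-fold higher number from compound 2 to compound 4 (0.55 log units; beyond the scatter) shows that it still trails methylamino. The step of a 4.9-fold lower number from compound 3 to compound 4 (0.69 log units; beyond the scatter) alters both the size of the group and the hydrogen on its nitrogen, so these two differences cannot be separated here. Nothing at hand explains these differences.
On these data alone, whether ethylamino or cyclopropylamino would come closer to methylamino stays open. So does the effect of a methyl group added to the nitrogen of isopropylamino.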